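This account rests on a few compounds, and the source may have more. Where it says the series, first, only, none or still open, it means among the compounds named here.

Measured so far in a functional assay on MCF7 cells (Homo sapiens) for antiproliferative activity, read by MTT assay, with a stated time of 72 h; on this read-out higher numbers stand for weaker inhibition and lower numbers for stronger inhibition:
- compound 1 `COc1ccc(-c2cn(C/C=C3\OC(=O)C(OCc4ccccc4)=C3OCc3ccccc3)nn2)cc1`: 39100 nM
- compound 2 `O=C1O/C(=C\Cn2cc(-c3cc(F)cc(F)c3)nn2)C(OCc2ccccc2)=C1OCc1ccccc1`: > 100000 nM
- compound 3 `C[Si](C)(C)c1cn(C[C@H](O)[C@H]2OC(=O)C(OCc3ccccc3)=C2OCc2ccccc2)nn1`: 12100 nM

Compound 3 gives the lowest of the two numbers; its nearest neighbour is compound 1, whose number is higher by a margin beyond the scatter. For compound 2 the read-out is a limit, not a number (the limit of > 100000 nM in this assay, at which 1 of the 3 values shown sits). For the measured compounds named here, the one step measured, an at least 2.5-fold higher number from compound 1 to compound 2 (0.40 log units; beyond the scatter), concerns the aryl group on the five-membered ring and sits at a different place from the change now in question.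

Compound 4 `O=C1O[C@H]([C@@H](O)Cn2ccnn2)C(OCc2ccccc2)=C1OCc1ccccc1` differs from compound 3 as follows: a hydrogen atom in place of a group of 4 heavy atoms (3 carbon, 1 silicon; no ring), on an aromatic carbon. Going by the values given here, no measured step changes this position, so the step from compound 1 to compound 2 bears on it only by showing that substitution on the five-membered ring can move the number by a modest amount. The expectation is that compound 4 gives a number somewhat higher than compound 3, with the direction uncertain and the step modest rather than large. Compound 4 is estimated at 30000 nM, with a range from 10000 nM to 100000 nM. The expected step is a 2.5-fold higher number from compound 3 to compound 4 (0.39 log units; beyond the scatter).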

Compound 4, half-maximal inhibitory concentration: > 100000 nM
Compound 4 gave a limit, no number; the forecaster's own chance of this, stated with the estimate: 20%; middle value at least 3.3-fold (0.52 log units) away from the limit.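

In this assay, the aromatic carbon of the five-membered aromatic ring with 3 nitrogen now has a measured step of its own: a hydrogen atom in place of the group of 4 heavy atoms (3 carbon, 1 silicon; no ring) gives an at least 8.2-fold higher number from compound 3 to compound 4 (0.91 log units; beyond the scatter) and so takes the core of compound 3 from a measurable number to no number at all. For the compounds shown here, the earlier step showed only one aryl group exchanged for another on this ring, on a different core, and left open whether the core of compound 3 needs any group at this carbon; in this pair, the ring carrying only hydrogen there does not reach a measurable number. Compound 4 sits at a limit, so the full size of the step cannot be read: the limit of > 100000 nM in this assay, at which 2 of the 4 values shown sit.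

As far as these compounds go, whether the silicon atom itself matters stays open, and a tert-butyl group at this carbon on the core of compound 3, with carbon where the silicon stands, would address that directly. Also open, from the compounds shown here alone, is how this carbon tolerates other groups on that core, such as a phenyl ring, an aminomethyl group or a longer alkyl chain.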